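Acid side chain on the shared core: ether versus ethylene

This account rests on a few compounds, and the source may have more. Where it says the series, first, only, none or still open, it means among the compounds named here.

Measured compounds:
compound 1 `O=C(O)c1cc(=O)oc2cc(OCc3cccc(Cl)c3)ccc12` gives 100000 nM in an assay on brain (strain Sprague-Dawley) for inhibition of Amine oxidase [flavin-containing] B (Rattus norvegicus), read by spectrophotometry; on this read-out lower numbers stand for stronger inhibition and higher numbers for weaker inhibition
compound 2 `O=C(O)COc1cc(=O)oc2cc(OCc3cccc(Cl)c3)ccc12` gives 31600 nM in this assay

Going by the values given here, compound 2 holds the lowest number of the two measured, compound 1 standing higher; the only measured step is a 3.2-fold lower number from compound 1 to compound 2 (0.50 log units; beyond the scatter). Compound 3 `O=C(O)CCc1cc(=O)oc2cc(OCc3cccc(Cl)c3)ccc12` differs from compound 2 by 2-carboxyethyl in place of carboxymethoxy on an aromatic carbon. The measured step concerns a different exchange and bears only loosely on this one, so no firm direction can be drawn from it. Compound 3 is therefore expected close to compound 2, with an estimated step of a 1.3-fold lower number from compound 2 to compound 3 (0.10 log units; within the scatter) within the scatter, the expected value being 25000 nM (range 8000 nM to 80000 nM).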

Compound 3, half-maximal inhibitory concentration: 1200 nM
Beside the measured number, compound 3's estimate is 21-fold (1.32 log units) above it; measured number outside the range, below it.
By their numbers in this assay, from the lowest: compound 3; then compound 2; then compound 1.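

In this assay this position responds strongly to how the acid is linked to the shared core: at an equal heavy-atom count, 2-carboxyethyl in place of carboxymethoxy gives a 26-fold lower number from compound 2 to compound 3 (1.42 log units; beyond the scatter) in this series. Against the directly attached carboxy, 2-carboxyethyl gives an 83-fold lower number from compound 1 to compound 3 (1.92 log units; beyond the scatter) and so far exceeds the ether-linked acid's gain. Nothing available explains the difference between the ether and ethylene links.

Still open, from the compounds shown here alone, is whether a longer chain, such as 3-carboxypropyl, lowers the number further. Also open, going by these compounds, is whether a primary amide or methyl ester can replace the carboxylic acid.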